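Extending Ethoxy to Butoxy on a Shared Core

The source may report more compounds than this note shows. Statements on the series, on what has been measured and on what is new or still open speak of the compounds shown alone.

In a functional assay on SK-N-MC cells (Homo sapiens) for cytotoxicity, read by MTT assay (a higher number here means a weaker inhibitor, a lower number a stronger inhibitor), compound 2 `CCOc1c(Br)cc(/C=C2\CCC/C(=C\c3cccc([N+](=O)[O-])c3)C2=O)cc1OC` gives 10.8 ug/mL, the higher of the two numbers recorded so far. Its nearest neighbour is compound 1 `COc1cc(/C=C2\CCC/C(=C\c3ccccc3[N+](=O)[O-])C2=O)cc(Br)c1OC`, which in this assay gives 6.24 ug/mL; the two values lie within the usual scatter of each other, so no order between them can be read. For the measured compounds named here, no step between measured compounds that differ in a single place is available, so any expectation for the next compound rests on these two values and on the structural change alone.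

Compound 3 `CCCCOc1c(Br)cc(/C=C2\CCC/C(=C\c3cccc([N+](=O)[O-])c3)C2=O)cc1OC` differs from compound 2 by ethyl in place of hydrogen on a saturated chain carbon, two bonds along the chain from an oxygen on an aromatic ring: read one bond further out, ethoxy becomes butoxy. Going by the values given here, the data offer no precedent for a change of this kind, and the two measured values do not separate beyond the scatter. The step is therefore expected to be small, most likely none beyond the scatter, with no direction that can be called on the present evidence. Compound 3 is expected to give 12 ug/mL in this assay, with a range from 5 ug/mL to 28 ug/mL. This amounts to an expected 1.1-fold higher number from compound 2 to compound 3 (0.05 log units; within the scatter).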

Compound 3, half-maximal inhibitory concentration: 25.4 ug/mL
Beside the measured number, compound 3's estimate is 2.1-fold (0.33 log units) below it; low and high end bracket the measured number.
By their numbers in this assay, from the lowest: compounds 1 and 2 (each within the scatter of the next); then compound 3.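

Extending ethoxy to butoxy, with ethyl in place of hydrogen on a saturated chain carbon, two bonds along the chain from an oxygen on an aromatic ring, brings a 2.4-fold higher number from compound 2 to compound 3 (0.37 log units; beyond the scatter) in this assay. The step is modest, but it shows that this position is not indifferent to chain length, since the longer chain gives the weaker inhibitor of this pair. Compounds 1 and 2 differ in more than one place and offered no such single-change reading, yet this remains one step on one core, and nothing at hand accounts for it.

On these data alone, whether the number keeps rising with a longer chain such as hexyloxy, falls back with propoxy in between, or changes differently when the chain ends in an amine or a carboxylic acid stays open. As far as these compounds go, it is also open whether butoxy in place of the corresponding group on the core of compound 1 would bring a step of similar size and the same direction, so the reading cannot yet be carried beyond compound 2 and compound 3.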